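The compounds below may be only part of what the source reports. "The series", "measured", "known", "first", "only" and "open" are said of these compounds alone.

Compound 1 `COc1ccc2c(/C=C(\C#N)C(=O)c3c[nH]c4cc(F)ccc34)c[nH]c2c1` was tested in a functional assay on PC-3 cells (Homo sapiens) for cytotoxicity, read by WST assay, with a stated time of 24 h; a higher number here means a weaker inhibitor, a lower number a stronger inhibitor. Compound 1 reads > 50000 nM, which is a limit of the assay and not a number. Compound 2 `N#C/C(=C\c1c[nH]c2cc(F)ccc12)C(=O)c1c[nH]c2cc(F)ccc12` reads > 50000 nM, again a limit. Compound 3 `COc1ccc2[nH]cc(/C=C(\C#N)C(=O)c3c[nH]c4ccc(OC)cc34)c2c1` reads > 50000 nM, likewise a limit. Compound 1 therefore has no exact position, and the whole record amounts to the limit of > 50000 nM in this assay, at which 3 of the 3 values shown sit.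

Compound 4 `COc1ccc2c(/C=C(\C#N)C(=O)c3c[nH]c4ccccc34)c[nH]c2c1` differs from compound 1 as follows: hydrogen in place of fluoro on an aromatic carbon. This puts hydrogen in place of fluoro on an aromatic carbon. The only measured step between two of these compounds is a step that the two limits leave unreadable from compound 1 to compound 2, with fluoro in place of methoxy on an aromatic carbon, and it offers no size to carry over. With no readable step to draw on, no change beyond the scatter is expected in this assay, in either direction. The expected step is a step that the limit leaves unreadable from compound 1 to compound 4. For compound 4 the estimated value is 60000 nM, with an expected range from 25000 nM to 150000 nM, and the assay may well report only a limit again.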

Compound 4, half-maximal inhibitory concentration: 33300 nM
Compound 4: the middle estimate sits 1.8-fold (0.26 log units) above what was measured; the range from low to high includes it.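

In this assay, hydrogen in place of fluoro on this aromatic carbon, meta to a fused ring and para to a fused ring, gives an at least 1.5-fold lower number from compound 1 to compound 4 (0.17 log units; that floor lies within the scatter). Within the data shown here, this is the first change with any readable size, though only a floor can be given, since one end of the step is a limit and the true size could be larger. Compound 4 is the only compound shown with an exact number, and the others give only a limit: the limit of > 50000 nM in this assay, at which 3 of the 4 values shown sit.

The compounds shown leave open whether an amine or a carboxylic acid on this same carbon would give a lower or a higher number in this assay. They also leave open whether the step would hold with the methoxy of compound 1 replaced by hydrogen.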